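Adding a Second Fluorine to a Lactone-Free Analogue

The compounds below may be only part of what the source reports. "The series", "measured", "known", "first", "only" and "open" are said of these compounds alone.

Compound 1 `O=C1OC[C@H](Cc2ccccc2)[C@H]1Cc1ccc(Cl)c(Cl)c1` gives 19000 nM in a functional assay on HL-60 cells (Homo sapiens) for cytotoxicity, read by WST assay, with a stated time of 48 h; on this read-out higher numbers stand for an effect only at larger amounts of compound and lower numbers for an effect already at smaller amounts. Compound 2 `O=C1OC[C@H](Cc2ccc(F)cc2)[C@H]1Cc1ccc(Cl)c(Cl)c1` differs from it by a single change, (fluoro in place of hydrogen on an aromatic carbon), and in this assay compound 2 gives 14000 nM; the step of a 1.4-fold lower number from compound 1 to compound 2 (0.13 log units; within the scatter). Compound 3 `Fc1ccc(C[C@H]2COC[C@@H]2Cc2ccc(Cl)c(Cl)c2)cc1` carries a different core; the difference between the two cores is not broken down here. In this assay compound 3 gives 43000 nM. Compound 4 `Fc1ccc(C[C@H]2COC[C@@H]2Cc2ccc(Cl)c(Cl)c2)cc1F` has not yet been measured and differs from compound 3 by fluoro in place of hydrogen on an aromatic carbon. The surroundings are not identical: in compound 2 the entering fluoro stands para to a large group, whereas in compound 4 it stands ortho to a fluoro group and meta to a large group, so this is the same kind of change, not the same change. Because the earlier step of a 1.4-fold lower number from compound 1 to compound 2 (0.13 log units; within the scatter) stayed within the scatter, compound 4 is expected to move little from compound 3, with an estimated step of a 1.2-fold lower number from compound 3 to compound 4 (0.09 log units; within the scatter) in this assay. Compound 4 is accordingly estimated at 35000 nM, with a likely range from 15000 nM to 80000 nM.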

Compound 4, half-maximal effective concentration: 18000 nM
Beside the measured number, compound 4's estimate is 1.9-fold (0.29 log units) above it; the range from low to high includes it.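

On the core of compound 3, fluoro in place of hydrogen on an aromatic carbon, ortho to a fluoro group and meta to a large group, gives in this assay a 2.4-fold lower number from compound 3 to compound 4 (0.38 log units; beyond the scatter) as a modest step. The earlier step on the core of compound 1 stayed within the scatter and this one lies beyond it, yet the gap between the two is itself no larger than the scatter of two such steps: the same change on two cores in this assay, a 1.4-fold lower number (0.13 log units; within the scatter) from compound 1 to compound 2 and a 2.4-fold lower number (0.38 log units; beyond the scatter) from compound 3 to compound 4, 1.8-fold (0.25 log units) apart, within the scatter of two such steps. This shows no measurable difference in how the change carries from one core to the other, but it rests on a single pair per core with the fluoro entering in different surroundings, so it does not show that the step is the same on both.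

The compounds shown leave open whether a second fluoro on the core of compound 1 would give a similar step. They also leave open how a methoxy group, a nitrile or an amine at the same place would behave on either core.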